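Swapping the anilide ring: from methoxy to chlorine

The source may report more compounds than this note shows. Statements on the series, on what has been measured and on what is new or still open speak of the compounds shown alone.

Measured so far:
Compound 1, `Cc1cc(C)cc(NC(=O)COc2cc(C)nc3ccc(OC(F)(F)F)cc23)c1`: > 100000 nM
Compound 2, `CCCc1cc(OCC(=O)Nc2cc(C)cc(C)c2)c2cc(OC)ccc2n1`: 12600 nM
Compound 3, `COc1cccc(NC(=O)COc2cc(C)nc3ccc(OC)cc23)c1`: > 100000 nM

In a toxicity assay on HepG2 cells (Homo sapiens) for inhibition, read by CellTiter-Glo, with a stated time of 48 h (on this read-out lower numbers stand for stronger inhibition and higher numbers for weaker inhibition), compound 3 gives > 100000 nM, which is a limit of the assay rather than a number. Compound 1 sits at the same kind of limit with > 100000 nM. Of the three compounds shown, only compound 2 gives a number in this assay, at 12600 nM. Compound 3 therefore stands among the weaker members of this small set; the limit of > 100000 nM in this assay, at which 2 of the 3 values shown sit, is where two of the three values rest.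

The next compound, compound 4 `COc1ccc2nc(C)cc(OCC(=O)Nc3ccc(Cl)cc3)c2c1`, differs from compound 3 in one place: 4-chlorophenyl in place of 3-methoxyphenyl on an amide-type nitrogen. The shared core and the amide linker are unchanged.

For the measured compounds named here, no step between two measured compounds is available here, so the expected size of this change rests only on the values shown. With two of three values at the limit, compound 4 is expected to stay weak as well, and the step of an at least 1.6-fold lower number from compound 3 to compound 4 (0.22 log units; that floor lies within the scatter) is estimated to be small or none beyond the scatter. Compound 4 is expected to give about 60000 nM in this assay, with a range from 15000 nM to 150000 nM.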

Compound 4, half-maximal inhibitory concentration: > 100000 nM
Compound 4 gave a limit, no number; the forecaster's own chance of this, stated with the estimate: 55%; at least 1.6-fold (0.22 log units) between middle value and limit.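

In this assay compound 4 gives > 100000 nM, which is a limit and not a number. For the compounds shown here, compound 3 also sits at a limit, so no step between compound 3 and compound 4 can be read. Most of the set now rests at one point: the limit of > 100000 nM in this assay, at which 3 of the 4 values shown sit. The compounds shown leave open whether 4-chlorophenyl and 3-methoxyphenyl differ at all on this read-out.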